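The source may hold more compounds than are shown below. What is called first, only, known or untested is meant among the compounds shown, and "the series" means these compounds.

Measured so far:
- compound 1 `CC[C@H](C)[C@H](NC(=O)c1cccc(Cn2ccnc2)c1)C(=O)NNC(=O)OC(C)(C)C`: in an assay on HEK293 cells for displacement of a labelled ligand from Type-2 angiotensin II receptor (Homo sapiens) (a higher number here means a weaker inhibitor, a lower number a stronger inhibitor), compound 1 gives > 100000 nM
- compound 2 `CC[C@H](C)[C@H](NC(=O)c1cccc(Cn2ccnc2)c1)C(N)=O`: in this assay compound 2 gives "not determined" (no result reported)

Compound 1 stands only at a limit of this assay, (the limit of > 100000 nM in this assay, at which 1 of the 2 values shown sits). Among the measured compounds shown here, compound 2 stands nowhere on the numbers: this assay holds no value for it, and no step between measured compounds is available.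

Compound 3 `CC[C@H](C)[C@H](NC(=O)c1cccc(Cn2ccnc2)c1)C(=O)NNS(=O)(=O)c1ccc(C)cc1` differs from compound 2 by ((4-methylphenyl)sulfonyl)amino in place of hydrogen on an amide-type nitrogen. For the measured compounds named here, with no measured step as anchor, only a rough expectation is possible. In this assay a large step towards a stronger inhibitor is expected for compound 3 relative to compound 2, with wide uncertainty. Compound 3 is expected near 5000 nM, with a range from 200 nM to 100000 nM.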

Compound 3, inhibition constant: 29000 nM
Compound 3: middle estimate off by 5.8-fold (0.76 log units), on the low side; the range from low to high includes it.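

With (4-methylphenyl)sulfonyl in place of tert-butoxycarbonyl on the amine nitrogen, this assay shows an at least 3.4-fold lower number from compound 1 to compound 3 (0.53 log units; beyond the scatter). The group on this nitrogen therefore matters, and compound 3 gives a true number where compound 1 does not. The full size of the step stays unknown, since the value of compound 1 is a limit: the limit of > 100000 nM in this assay, at which 1 of the 3 values shown sits.

Left open is whether the sulfonyl or the 4-methylphenyl ring accounts for the step. A methanesulfonyl or benzoyl group on the same nitrogen would separate the two.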